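The source may report more compounds than this note shows. Statements on the series, on what has been measured and on what is new or still open speak of the compounds shown alone.

Measured compounds:

Compound 1, `COc1ccc(C2=NN(C3=NC(=O)/C(=C4\C(=O)Nc5ccc(Br)cc54)S3)C(c3ccc(OC)cc3)C2)cc1`, gives 405 nM in a functional assay on cells (Cancer cell lines, Homo sapiens) for cytotoxicity, read by sulforhodamine B assay, with a stated time of 48 h; a lower number here means a stronger inhibitor of growth, a higher number a weaker inhibitor of growth.
Compound 2, `COc1ccc(C2=NN(C3=NC(=O)/C(=C4\C(=O)Nc5ccc(Cl)cc54)S3)C(c3ccc(OC)cc3)C2)cc1`, gives 420 nM in this assay.
Compound 3, `COc1ccc(C2=NN(C3=NC(=O)/C(=C4\C(=O)Nc5ccc(Br)cc54)S3)C(c3ccc(Cl)cc3)C2)cc1`, gives 1480 nM in this assay.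

Compound 4, `COc1ccc(C2=NN(C3=NC(=O)/C(=C4\C(=O)Nc5ccc(Cl)cc54)S3)C(c3ccc(Cl)cc3)C2)cc1`, has not yet been measured in this assay.

The three measured compounds share a core that carries a halogen on one ring and a substituted phenyl on another. Compound 1 and compound 2 differ only in the halogen: chloro in place of bromo on an aromatic carbon. That exchange left the growth-inhibiting concentration essentially unchanged, a 1.0-fold higher number from compound 1 to compound 2 (0.02 log units; within the scatter). The change from compound 1 to compound 3 is of a different kind, (chloro in place of methoxy on an aromatic carbon), and it cost potency: a 3.7-fold higher number from compound 1 to compound 3 (0.56 log units; beyond the scatter). Compound 3 therefore stands as the weakest of the three measured compounds, its steps to both others lying beyond the scatter.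

Compound 4 is related to compound 3 exactly as compound 2 is related to compound 1: chloro in place of bromo on an aromatic carbon. The place of the exchange is described in the same words for both pairs, so this is the same change made on a different core, the two cores differing as described for compound 1 and compound 3. Because the earlier instance of this change, a 1.0-fold higher number from compound 1 to compound 2 (0.02 log units; within the scatter), stayed within the scatter, the step from compound 3 to compound 4 is expected to be similarly small, a 1.0-fold higher number from compound 3 to compound 4 (0.01 log units; within the scatter). Compound 4 is thus estimated at 1500 nM, with a plausible range from 700 nM to 3200 nM.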

Compound 4, concentration for total growth inhibition: 430 nM
Beside the measured number, compound 4's estimate is 3.5-fold (0.54 log units) above it; measured number outside the range, below it.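

Chloro in place of bromo on an aromatic carbon changed almost nothing on the core of compound 1, yet on the core of compound 3 it gave a 3.4-fold lower number from compound 3 to compound 4 (0.54 log units; beyond the scatter) in this assay, so this change does not keep one size from core to core: the same change on two cores in this assay, a 1.0-fold higher number (0.02 log units; within the scatter) from compound 1 to compound 2 and a 3.4-fold lower number (0.54 log units; beyond the scatter) from compound 3 to compound 4, 3.6-fold (0.55 log units) apart, beyond the scatter of two such steps

Seen from the other side, chloro in place of methoxy cost potency when the bromo was present but gave a 1.0-fold higher number from compound 2 to compound 4 (0.01 log units; within the scatter) when chloro stood there instead, so the two exchanges do not simply add up in these four compounds: the same change on two cores in this assay, a 3.7-fold higher number (0.56 log units; beyond the scatter) from compound 1 to compound 3 and a 1.0-fold higher number (0.01 log units; within the scatter) from compound 2 to compound 4, 3.6-fold (0.55 log units) apart, beyond the scatter of two such steps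

Within the data shown here, this does not show why the two exchanges interact, and it gives no general rule: both gaps run through compound 3, which gives 1480 nM, and each change is seen on only two cores.

The compounds shown leave open whether the same interplay appears with other groups, such as fluoro or iodo in place of the bromo, or a hydroxyl or a dimethylamino group in place of the methoxy. They also leave open whether a repeat measurement of compound 3 would hold its value, since so much of the comparison rests on that single number.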